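The compounds below may be only part of what the source reports. "The series", "measured", "known", "first", "only" and "open" are said of these compounds alone.

In a functional assay on HeLa cells (Homo sapiens) for inhibition, read by sulforhodamine B assay (a lower number here means a stronger inhibitor, a higher number a weaker inhibitor), compound 1 `O=C1C=C(NC2CCCCC2)C(=O)c2c1nc1n2[C@H]2OC[C@@H](O)[C@H]2OC1` gives > 16000 nM, which is a limit of the assay and not a number. Going by the values given here, compound 2 `O=C1C=C(Nc2cccc(F)c2)C(=O)c2c1nc1n2[C@H]2OC[C@@H](O)[C@H]2OC1`, at 6440 nM, therefore holds the only actual number so far. Compound 3 `COc1ccccc1NC1=CC(=O)c2nc3n(c2C1=O)[C@H]1OC[C@@H](O)[C@H]1OC3` keeps the shared core and differs from compound 2 at one place: 2-methoxyphenyl in place of 3-fluorophenyl on an amine nitrogen. Among the compounds with values here, only one measured step bears on this, an at least 2.4-fold lower number from compound 1 to compound 2 (0.39 log units; beyond the scatter), and it exchanged cyclohexyl for 3-fluorophenyl at the same nitrogen. Within the data shown here, the change to compound 3 keeps an aromatic ring there, and no measured step compares two such rings, so a shift beyond the scatter is not expected in this assay. The expected step is a 1.1-fold lower number from compound 2 to compound 3 (0.03 log units; within the scatter). Compound 3 is estimated at 6000 nM, with an expected range from 2000 nM to 16000 nM.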

Compound 3, half-maximal inhibitory concentration: 2950 nM
Compound 3: the middle estimate sits 2.0-fold (0.31 log units) above what was measured; the range from low to high includes it.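

In this assay, going by these compounds alone, the earlier compounds compared only cyclohexyl with an aromatic ring at this amine nitrogen, whereas 2-methoxyphenyl in place of 3-fluorophenyl gives a 2.2-fold lower number from compound 2 to compound 3 (0.34 log units; beyond the scatter), so the choice of aromatic ring itself moves the number. Set against cyclohexyl, 2-methoxyphenyl gives an at least 5.4-fold lower number from compound 1 to compound 3 (0.73 log units; beyond the scatter). Compound 1 holds a limit of the assay and not a number, so this step is open-ended on that side: the limit of > 16000 nM in this assay, at which 1 of the 3 values shown sits.

The compounds shown do not separate the methoxy group from its place on the ring, a question that 3-methoxyphenyl or 2-fluorophenyl on the same nitrogen would address. Also open, on these data alone, is how plain phenyl or a 2-aminoethyl chain at this nitrogen would read in this assay.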